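A few compounds are considered here, and "the series" means these few. Any claim that something is new, unique, unknown or untested is made for them only; others in the source may bear on it.

In a functional assay on Bel-7402 cells (Homo sapiens) for inhibition, read by sulforhodamine B assay, with a stated time of 72 h (a lower number here means a stronger inhibitor, a higher number a weaker inhibitor), the series reads:
- compound 1 (`C[C@H](Nc1nc(N)nc(N)c1C#N)c1nn(-c2cccc(S(C)(=O)=O)c2)c2cc(F)ccc12`) gives 22100 nM
- compound 2 (`C[C@H](Nc1nc(N)nc2[nH]cnc12)c1nn(-c2cccnc2)c2cc(F)ccc12`) gives > 40000 nM as a limit of the assay
- compound 3 (`C[C@H](Nc1ncnc2[nH]cnc12)c1nn(-c2ccc(C#N)cc2)c2cc(F)ccc12`) gives 31500 nM

Compound 3 at 31500 nM and compound 1 at 22100 nM lie within the scatter of each other. Among the compounds with values here, the only other reading, for compound 2, is a limit and not a number.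

Compound 4 (`C[C@H](Nc1ncnc2[nH]cnc12)c1nn(-c2ccncc2)c2cc(F)ccc12`) has pyridin-4-yl in place of 4-cyanophenyl on an aromatic nitrogen of a five-membered aromatic ring with 2 nitrogen, part of a fused or bridged system of two rings (pyridin-4-yl in place of 4-cyanophenyl on an aromatic nitrogen). Within the data shown here, no measured pair isolates this change. The expectation therefore starts from compound 3 at 31500 nM and assumes no shift in either direction in this assay beyond the scatter. The estimated change is a 1.0-fold higher number from compound 3 to compound 4 (0.02 log units; within the scatter) and so remains within that scatter. A reading reported only as a limit is also expected to be quite possible. The estimate for compound 4 is 33000 nM (expected range 15000 nM to 60000 nM).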

Compound 4, half-maximal inhibitory concentration: > 40000 nM
Compound 4 gave a limit, no number (the forecaster's own chance of this, stated with the estimate: 40%); middle value at least 1.2-fold (0.08 log units) away from the limit.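

In this assay, pyridin-4-yl in place of 4-cyanophenyl on an aromatic nitrogen gives an at least 1.2-fold higher number from compound 3 to compound 4 (0.10 log units; that floor lies within the scatter). Compound 4 gives > 40000 nM, which is a limit of the assay and not a number. This is the first direct reading at this position: the exchange of the carbon-only ring with its nitrile for a ring with one hetero atom brings no lower number, and the floor of the step does not separate the two compounds, while the series sits close to its upper reading limit: the limit of > 40000 nM in this assay, at which 2 of the 4 values shown sit.

From the compounds shown here alone, the true size of the step stays open, as does any real difference between these two groups. Also open, going by these compounds, is whether a substituent such as an amine or a carboxylic acid on the aromatic ring at this position would give a clearly lower number.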